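A Third Chlorine on the Aryl Ring of Two Cores

The source may hold more compounds than are shown below. What is called first, only, known or untested is meant among the compounds shown, and "the series" means these compounds.

Compound 1 `NC1=NC2(CCSCC2)N(OCCCOc2ccc(Cl)c(Cl)c2)C(N)=N1` and compound 2 `NC1=NC2(CCSCC2)N(OCCCOc2cc(Cl)c(Cl)cc2Cl)C(N)=N1` share one core and differ in a single place, described by chloro in place of hydrogen on an aromatic carbon. In an assay on isolated protein for inhibition of Dihydrofolate reductase (Homo sapiens), read by spectrophotometry, using NADPH, with stated times of 5 s and 6 min, tested at 5 uM (on this read-out lower numbers stand for a weaker effect and higher numbers for a stronger effect at the one concentration tested), compound 1 gives 88.4%. In this assay compound 2 gives 84.4%. The step of a number 4 percentage points lower from compound 1 to compound 2 (within the scatter) is small, so the two values are not distinguished from each other.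

Compound 3 `NC1=NC2(CCOCC2)N(OCCCOc2ccc(Cl)c(Cl)c2)C(N)=N1` carries a different core; how the core of compound 3 differs from the core of compound 1 is not broken down here. In this assay compound 3 reads > 90%, which is a limit of the assay rather than a number, as noted in the limit of > 90% in this assay, at which 1 of the 3 values shown sits.

Compound 4 `NC1=NC2(CCOCC2)N(OCCCOc2cc(Cl)c(Cl)cc2Cl)C(N)=N1` has not yet been measured. It differs from compound 3 by chloro in place of hydrogen on an aromatic carbon, the same change already seen between compound 1 and compound 2. In this assay compound 4 is expected to give 88%, an estimated step of a number at least 2 percentage points lower from compound 3 to compound 4 (that floor lies within the scatter). That expectation rests on the step of a number 4 percentage points lower from compound 1 to compound 2 (within the scatter) and on compound 3 sitting at a limit.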

Compound 4, a percentage reported as inhibition, at one concentration (the size of the read-out at that concentration, not a potency): > 90%
Compound 4: a limit, no number; the forecaster's own chance of this, stated with the estimate: 50%; middle value at least 2 percentage points away from the limit.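

In this assay compound 4 reads > 90%, which is a limit of the assay and not a number. Compound 3 sits at a limit as well, so no step between compound 3 and compound 4 can be read: the limit of > 90% in this assay, at which 2 of the 4 values shown sit.

The compounds shown leave open whether going from 3,4-dichlorophenyl to 2,4,5-trichlorophenyl alters inhibition on the core of compound 3.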